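Swapping a urea for a benzylamine on a shared core

The source may hold more compounds than are shown below. What is called first, only, known or untested is meant among the compounds shown, and "the series" means these compounds.

Compound 1 `O=C(Nc1ncc(C(=O)O)c2nc(-c3ccco3)nn12)NC1CCCCC1`: > 100000 nM
Compound 2 `CCOC(=O)c1cnc(NCc2ccc(F)cc2)n2nc(-c3ccco3)nc12`: 932 nM

In an assay on CHO cells for displacement of a labelled ligand from adenosine receptor A1 (Homo sapiens) (on this read-out lower numbers stand for stronger inhibition and higher numbers for weaker inhibition), compound 1 gives > 100000 nM, which is a limit of the assay rather than a number, so its place on the scale is known only as the limit of > 100000 nM in this assay, at which 1 of the 2 values shown sits. Compound 2 gives 932 nM in this assay. Compound 3 `O=C(O)c1cnc(NCc2ccc(Cl)cc2)n2nc(-c3ccco3)nc12` has not yet been measured; it differs from compound 1 by 4-chlorobenzyl in place of cyclohexylcarbamoyl on a nitrogen on an aromatic ring. Within the data shown here, with no measured step between compounds that share this change, the expected direction is toward stronger binding, with the size uncertain. Compound 3 is expected to reach about 20000 nM, between 2000 nM and 100000 nM, an estimated step of an at least 5.0-fold lower number from compound 1 to compound 3 (0.69 log units; beyond the scatter).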

Compound 3, inhibition constant: > 100000 nM
Compound 3: a limit, no number; the forecaster's own chance of this, stated with the estimate: 35%; middle value at least 5.0-fold (0.69 log units) away from the limit.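

Compound 1 and compound 3 each give a limit of the assay rather than a number, so no step can be read between them: the limit of > 100000 nM in this assay, at which 2 of the 3 values shown sit.

On these data alone, whether 4-chlorobenzyl in place of cyclohexylcarbamoyl changes binding at all, and by how much, stays open.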